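Cytotoxicity notes: from compound 2 to compound 3

A few compounds are considered here, and "the series" means these few. Any claim that something is new, unique, unknown or untested is made for them only; others in the source may bear on it.

Measured so far in an ADME assay on cells (Homo sapiens) for cytotoxicity, read by polymerase chain reaction, with a stated time of 3 days; on this read-out lower numbers stand for higher toxicity in this test and higher numbers for lower toxicity in this test:
compound 1, `Nc1nc(Cl)c(-c2ccccn2)c(N[C@@H]2C[C@H](CO)[C@@H](O)[C@H]2O)n1`, gives > 25000 nM, a limit of the assay rather than a number.
compound 2, `Nc1nc(Cl)c(-c2nc3ccc(Cl)cc3s2)c(N[C@@H]2C[C@H](CO)[C@@H](O)[C@H]2O)n1`, gives 16000 nM.

For the measured compounds named here, compound 2 therefore holds the only number in this assay; the one other value, that of compound 1, is a limit (the limit of > 25000 nM in this assay, at which 1 of the 2 values shown sits).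

Compound 3, `CNc1ccc2nc(-c3c(Cl)nc(N)nc3N[C@@H]3C[C@H](CO)[C@@H](O)[C@H]3O)sc2c1`, is not yet measured. It differs from compound 2 by methylamino in place of chloro on an aromatic carbon. Going by the values given here, no step between measured compounds touches this position, so nothing in the present numbers sets a direction. The working expectation is a step from compound 2 to compound 3 of about a 1.3-fold higher number from compound 2 to compound 3 (0.10 log units; within the scatter), that is, none clearly beyond the usual scatter, with the possibility that only a limit is reported.

On that basis compound 3 is expected to give roughly 20000 nM in this assay, within a range from 8000 nM to 50000 nM.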

Compound 3, half-maximal cytotoxic concentration: 6000 nM
Estimate against measurement, compound 3: 3.3-fold (0.52 log units) above; the measured number lies below the stated range.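

In this assay, the place on the six-membered aromatic ring of carbon only turns out to matter for the read-out: methylamino in place of chloro gives a 2.7-fold lower number from compound 2 to compound 3 (0.43 log units; beyond the scatter), which points toward higher toxicity in this test. This is the only step shown that touches this position, and it shows that a single exchange of one small group there is enough to move the number beyond the usual scatter. Nothing at hand gives a measured property that would account for this step.

A single exchange cannot separate the part played by the nitrogen from that of its methyl group. From the compounds shown here alone, a free amine, dimethylamino or methoxy at the same place would bear on that, and whether the step carries over to other compounds stays open.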